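The compounds below may be only part of what the source reports. "The series", "measured", "known", "first", "only" and "open" are said of these compounds alone.

Within the data shown here, in a functional assay on DU-145 cells (Homo sapiens) for inhibition, read by trypan blue exclusion, with a stated time of 96 h (a higher number here means a weaker inhibitor of growth, a lower number a stronger inhibitor of growth), compound 1 `Cc1ccc(S/C(=C/c2c[nH]c3ccccc23)C(=O)c2ccc(Br)cc2)cc1` gives 10000 nM, the lowest number of the three measured so far. Compound 2 `Cc1ccc(S/C(=C/c2sccc2C)C(=O)c2ccc(Br)cc2)cc1` gives 50000 nM, and compound 3 `Cc1ccc(S/C(=C/c2ccc(Cl)c(Cl)c2)C(=O)c2ccc(Br)cc2)cc1` gives 50000 nM. Replacing the 1H-indol-3-yl group with 3-methylthiophen-2-yl brings a 5.0-fold higher number from compound 1 to compound 2 (0.70 log units; beyond the scatter), and replacing it with 3,4-dichlorophenyl brings a 5.0-fold higher number from compound 1 to compound 3 (0.70 log units; beyond the scatter). The two replacements themselves show no change at the digits printed from compound 2 to compound 3 (within the scatter).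

Compound 4 `Cc1ccc(S/C(=C/c2c[nH]c3ccc(Cl)cc23)C(=O)c2ccc(Br)cc2)cc1` keeps the 1H-indol-3-yl group of compound 1 and differs by chloro in place of hydrogen on an aromatic carbon. Among the measured compounds shown here, no measured step makes this change, so the evidence is indirect. Compound 2 and compound 3 lose the whole group, and since compound 4 retains it, a smaller change than a 5.0-fold higher number from compound 1 to compound 3 (0.70 log units; beyond the scatter) is expected in this assay.

The expected step is a 1.4-fold lower number from compound 1 to compound 4 (0.15 log units; within the scatter), with no change beyond the scatter anticipated and the direction uncertain. For compound 4 the estimated value is 7000 nM, with an expected range from 2500 nM to 25000 nM.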

Compound 4, concentration for 50% growth inhibition: 1000 nM
Compound 4: middle estimate off by 7.0-fold (0.85 log units), on the high side, and the stated range ends above it.
By their numbers in this assay, from the lowest: compound 4; then compound 1; then compounds 2 and 3 (each within the scatter of the next).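

In this assay, among these compounds, the earlier compounds showed only that replacing the whole 1H-indol-3-yl group raises the number, and they said nothing about whether that group could be improved by substitution. Compound 4 shows that it can: chloro in place of hydrogen on an aromatic carbon of the six-membered ring of the fused system, meta to a fused ring and para to a fused ring, brings a 10-fold lower number from compound 1 to compound 4 (1.00 log units; beyond the scatter), a step beyond the scatter from a change of a single heavy atom. Nothing available explains this gain.

The compounds shown leave open whether fluoro, bromo, methoxy or an amine on this same carbon would move the number as chloro does. They also leave open whether chloro on another carbon of this ring would have the same result.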